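Halogen swap on the aniline ring: bromo to iodo

A few compounds are considered here, and "the series" means these few. Any claim that something is new, unique, unknown or untested is made for them only; others in the source may bear on it.

Measured so far:
- compound 1 `O=C(Nc1ccc(Br)cc1F)c1cc(F)ccc1O`: 7900 nM
- compound 2 `O=C(Nc1ccc(Br)cc1F)c1cc(Cl)ccc1O`: 7800 nM

Both compounds were tested in an ADME assay on RAW264.7 cells (Mus musculus) for cytotoxicity, read by MTT assay, with a stated time of 24 h; a higher number here means that more compound is tolerated, a lower number that less compound is tolerated. Compound 2 gives the lowest of the two numbers, but its neighbour compound 1 sits within the scatter of it, so the two cannot be told apart. Among the measured compounds shown here, the one measured step, a 1.0-fold lower number from compound 1 to compound 2 (0.01 log units; within the scatter), shows that exchanging one halogen for another on the phenol ring left the number essentially unchanged.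

Compound 3 `O=C(Nc1ccc(I)cc1F)c1cc(Cl)ccc1O` is not yet measured. It differs from compound 2 by iodo in place of bromo on an aromatic carbon. For the measured compounds named here, this is again a halogen-for-halogen exchange, now on the other ring, and the only comparable step available, from compound 1 to compound 2, stayed within the scatter. The expected step of a 1.1-fold lower number from compound 2 to compound 3 (0.05 log units; within the scatter) is therefore small, with no direction claimed beyond the scatter. Compound 3 is expected to give about 7000 nM in this assay, within a range of 3500 nM to 14000 nM.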

Compound 3, half-maximal cytotoxic concentration: 7600 nM
Compound 3: middle estimate off by 1.1-fold (0.04 log units), on the low side; measured number inside the range.
By their numbers in this assay, from the lowest: compounds 3, 2 and 1 (each within the scatter of the next).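

Iodo in place of bromo, para to a large group, gives a 1.0-fold lower number from compound 2 to compound 3 (0.01 log units; within the scatter) in this assay, so compounds 2 and 3 cannot be told apart. The earlier step changed a halogen on the other ring, and this one shows that a halogen exchange at this second site also stays within the scatter. No measured information is available to explain this result.

As far as these compounds go, all three compounds carry a halogen at both of these sites, so it remains open whether plain hydrogen at this position would give a number that can be told apart from theirs. From the compounds shown here alone, it also remains open whether a group of another kind there, such as an amine, a carboxylic acid or a longer carbon chain, would do so.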